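From pyridin-3-yl to butyl on a carbonyl carbon

This account rests on a few compounds, and the source may have more. Where it says the series, first, only, none or still open, it means among the compounds named here.

Compound 1 `C=C1CC[C@@H]2[C@](C)(COC(=O)c3ccccc3C(=O)O)[C@H](OC(=O)c3ccccc3C(=O)O)CC[C@@]2(C)[C@@H]1/C=C/C1=CCOC1=O`: > 1620000 nM (a limit)
Compound 2 `C=C1CC[C@@H]2[C@](C)(COC(=O)c3cccnc3)[C@H](O)CC[C@@]2(C)[C@@H]1C/C=C1\C=COC1=O`: 2050000 nM
Compound 3 `C=C1CC[C@@H]2[C@](C)(CO)[C@H](OC(=O)c3cccnc3)CC[C@@]2(C)[C@@H]1C/C=C1\C=COC1=O`: 337000 nM

All three compounds were tested in an ADME assay on HepG2 2.2.15 cells (Homo sapiens) for cytotoxicity, read by MTT assay; on this read-out higher numbers stand for lower toxicity in this test and lower numbers for higher toxicity in this test. For compound 1, > 1620000 nM is a limit of the assay and not a number. Compound 3 gives 337000 nM, the lower of the two actual numbers, while compound 2 gives 2050000 nM, a gap beyond the usual scatter.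

Compound 4 `C=C1CC[C@@H]2[C@](C)(CO)[C@H](OC(=O)CCCC)CC[C@@]2(C)[C@@H]1C/C=C1\C=COC1=O` shares the core of compound 3 and differs from it in one group: butyl in place of pyridin-3-yl on a carbonyl carbon. This places butyl in place of pyridin-3-yl on a carbonyl carbon. Going by the values given here, no measured pair isolates a change of this kind, so the data give no direct guide to its effect. The expectation therefore starts from compound 3 at 337000 nM and anticipates no step beyond the scatter in this assay, in either direction. The estimated change is a 1.1-fold lower number from compound 3 to compound 4 (0.05 log units; within the scatter). For compound 4 the expected value is 300000 nM, with an estimated range of 120000 nM to 900000 nM.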

Compound 4, half-maximal cytotoxic concentration: 126000 nM
The estimate for compound 4 lay 2.4-fold (0.38 log units) above the measured number; measured number inside the range.
By their numbers in this assay, from the lowest: compound 4; then compound 3; then compound 2.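

Placing butyl in place of pyridin-3-yl on this carbonyl carbon gives the first step in this assay that isolates a single change, and it is a real though modest one: a 2.7-fold lower number from compound 3 to compound 4 (0.43 log units; beyond the scatter). The group at this position therefore affects the read-out, and here the open chain, with no ring, gives the lower number and so the higher toxicity in this test. Compound 1 remains a limit and not a number, so it adds no measured value to this comparison: the limit of > 1620000 nM in this assay, at which 1 of the 4 values shown sits.

From the compounds shown here alone, whether a propyl chain, a longer chain or a phenyl ring on this carbonyl carbon would continue this step remains open. So does whether the step follows from losing the ring as a whole or only its nitrogen.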